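From 4-hydroxyphenyl to 2,6-dimethoxyphenyl

The source may report more compounds than this note shows. Statements on the series, on what has been measured and on what is new or still open speak of the compounds shown alone.

compound 1 `O=C(Cc1csc2nc(-c3ccc(Br)cc3)cn12)N/N=C/c1ccccc1`: 28200 nM
compound 2 `O=C(Cc1csc2nc(-c3ccc(Br)cc3)cn12)N/N=C/c1ccccc1O`: 7240 nM
compound 3 `O=C(Cc1csc2nc(-c3ccc(Br)cc3)cn12)N/N=C/c1ccc(O)cc1`: 23400 nM

These values come from a functional assay on UACC-62 cells (Homo sapiens) for inhibition, read by sulforhodamine B assay, with a stated time of 48 h; a higher number here means a weaker inhibitor of growth, a lower number a stronger inhibitor of growth. The three compounds share one core and differ only in the aromatic group on the carbon with a double bond to nitrogen. Adding hydroxy gives two different results: one step is a 3.9-fold lower number from compound 1 to compound 2 (0.59 log units; beyond the scatter), and the other is a 1.2-fold lower number from compound 1 to compound 3 (0.08 log units; within the scatter). Compound 3 therefore cannot be told apart from compound 1, and the one clear separation that reaches it is a 3.2-fold higher number from compound 2 to compound 3 (0.51 log units; beyond the scatter).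

Compound 4 `COc1cccc(OC)c1/C=N/NC(=O)Cc1csc2nc(-c3ccc(Br)cc3)cn12` carries a different group: 2,6-dimethoxyphenyl in place of 4-hydroxyphenyl on a carbon with a double bond to nitrogen. In words, this is 2,6-dimethoxyphenyl in place of 4-hydroxyphenyl on a carbon with a double bond to nitrogen. For the measured compounds named here, no measured step tests a methoxy group, so the hydroxy steps offer only loose guidance, and the largest of them is modest. No change beyond the scatter is therefore expected, though with wide uncertainty. The expected step is a 1.2-fold lower number from compound 3 to compound 4 (0.07 log units; within the scatter). Compound 4 is estimated at 20000 nM, within an expected range of 7000 nM to 55000 nM.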

Compound 4, concentration for total growth inhibition: 27500 nM
Compound 4: middle estimate off by 1.4-fold (0.14 log units), on the low side; low and high end bracket the measured number.
By their numbers in this assay, from the lowest: compound 2; then compounds 3, 4 and 1 (each within the scatter of the next).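

In this assay, replacing 4-hydroxyphenyl with 2,6-dimethoxyphenyl on the carbon with a double bond to nitrogen gives a 1.2-fold higher number from compound 3 to compound 4 (0.07 log units; within the scatter), and replacing phenyl with it gives a 1.0-fold lower number from compound 1 to compound 4 (0.01 log units; within the scatter), so this larger group, with no hydrogen-bond donor, cannot be told apart from either. The separation from 2-hydroxyphenyl remains, at a 3.8-fold higher number from compound 2 to compound 4 (0.58 log units; beyond the scatter), which leaves 2-hydroxyphenyl as the only one of the four aromatic groups that stands apart from the others. The data shown offer no measurement that explains this result.

Going by these compounds, it remains open whether 2-methoxyphenyl, with a single methoxy group, would match compound 2 or fall with compounds 1, 3 and 4. On these data alone, it also remains open whether an amine in place of the hydroxy of compound 2 would preserve its separation.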